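The source may hold more compounds than are shown below. What is called first, only, known or untested is meant among the compounds shown, and "the series" means these compounds.

Compounds measured in a functional assay on SK-N-SH cells (Homo sapiens) for inhibition, read by MTT assay; on this read-out lower numbers stand for stronger inhibition and higher numbers for weaker inhibition:
compound 1 `O=C(CN1CCN(c2ccccc2F)CC1)Nc1ccc(C(=O)/C=C/c2cn(Cc3ccc(Br)cc3)nn2)cc1` gives 12800 nM;
compound 2 `CCCCCCCCn1cc(/C=C/C(=O)c2ccc(NC(=O)CN3CCN(C(=O)OC(C)(C)C)CC3)cc2)nn1` gives 38000 nM;
compound 3 `CCCCCCCCCCn1cc(/C=C/C(=O)c2ccc(NC(=O)CBr)cc2)nn1` gives 8680 nM.

Among these three, compound 1 has the second highest number. Compound 3 lies nearest to it, within the scatter, so the two cannot be ranked against each other; compound 2 lies further off, with a higher number beyond the scatter. Compound 4 `O=C(CN1CCN(c2ccc([N+](=O)[O-])cc2)CC1)Nc1ccc(C(=O)/C=C/c2cn(Cc3ccc(Br)cc3)nn2)cc1` differs from compound 1 in one place: 4-nitrophenyl in place of 2-fluorophenyl on an amine nitrogen in a ring. Going by the values given here, no measured pair shows this change, so its effect is unknown. Compound 4 is expected to stay close to compound 1, with a step of a 1.1-fold lower number from compound 1 to compound 4 (0.03 log units; within the scatter) that need not exceed the scatter in either direction. The estimate for compound 4 in this assay is 12000 nM, between 5000 nM and 30000 nM.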

Compound 4, half-maximal inhibitory concentration: 26500 nM
For compound 4 the middle estimate is 2.2-fold (0.34 log units) below the measured one, and the stated range covers the measured number.
By their numbers in this assay, from the lowest: compounds 3 and 1 (each within the scatter of the next); then compounds 4 and 2 (each within the scatter of the next).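

In this assay the aryl group on the amine nitrogen in the ring is not a silent site: the swap to 4-nitrophenyl gives a 2.1-fold higher number from compound 1 to compound 4 (0.32 log units; beyond the scatter) and so modestly weakens inhibition. Going by these compounds alone, this is the first sign that this site responds to a change of its aryl group. Nothing available accounts for the shift.

The swap alters both the substituent and where it sits on the phenyl ring, and these two cannot be separated. Going by these compounds, it remains open how plain phenyl or an aminophenyl group on this nitrogen would read.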